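A few compounds are considered here, and "the series" means these few. Any claim that something is new, unique, unknown or untested is made for them only; others in the source may bear on it.

Compound 3 `CC(C)OC(=O)OCC(CO)CCn1cnc2cnc(N)nc21` belongs to a set of three carbonates on a shared core that were tested in a functional assay on Vero cells (Chlorocebus sabaeus) for cytotoxicity; on this read-out higher numbers stand for lower toxicity in this test and lower numbers for higher toxicity in this test. In this assay compound 3 gives only a limit, > 500000 nM. Compound 1 `CC(C)COC(=O)OCC(CO)CCn1cnc2cnc(N)nc21` likewise gives only a limit in this assay, > 500000 nM. Compound 2 `CCCCCOC(=O)OCC(CO)CCn1cnc2cnc(N)nc21` also gives only a limit in this assay, > 500000 nM. Compound 4 `CCCCOC(=O)OCC(CO)CCn1cnc2cnc(N)nc21` has not yet been measured; it differs from compound 3 by butyl in place of isopropyl on an oxygen next to a carbonyl group. The measured steps that bear on this change, a step that the two limits leave unreadable from compound 1 to compound 2, a step that the two limits leave unreadable from compound 1 to compound 3 and a step that the two limits leave unreadable from compound 2 to compound 3, all remain unreadable because of the limit of > 500000 nM in this assay, at which 3 of the 3 values shown sit. For compound 4 the expected outcome in this assay is therefore again that limit, an estimated step of a number no higher from compound 3 to compound 4 (the limit leaves the size open). Compound 4 is expected to give 500000 nM, in a range from 250000 nM to 1000000 nM.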

Compound 4, half-maximal cytotoxic concentration: > 500000 nM
Compound 4 was reported as a limit (the forecaster's own chance of this, stated with the estimate: 85%); the middle value sits exactly at the limit.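

Among these compounds, no step to compound 4 from compound 1, compound 2 or compound 3 can be read in this assay, because all of these results are limits: the limit of > 500000 nM in this assay, at which 4 of the 4 values shown sit. As far as these compounds go, whether these four compounds differ at all in this assay stays open.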